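A few compounds are considered here, and "the series" means these few. Any claim that something is new, unique, unknown or untested is made for them only; others in the source may bear on it.

Compound 1 `CCOC(=O)c1oc2ccc(N(Cc3ccccc3)S(=O)(=O)c3ccc(Br)cc3)cc2c1C` gives 8700 nM in a functional assay on HCT-116 cells (Homo sapiens) for inhibition, read by MTT assay, with a stated time of 72 h; a lower number here means a stronger inhibitor, a higher number a weaker inhibitor.
Compound 2 `CCOC(=O)c1oc2ccc(N(Cc3ccccc3)S(=O)(=O)c3cccc(Cl)c3)cc2c1C` reaches only the limit of this assay, > 40000 nM.

Compound 2 therefore stands at the weak end of the two numbers shown: its value is a limit rather than a measured figure, and the step of an at least 4.5-fold higher number from compound 1 to compound 2 (0.66 log units; beyond the scatter) is itself only a lower bound on the loss. Compound 3 `CCOC(=O)c1oc2ccc(N(Cc3ccccc3)S(=O)(=O)c3ccccc3)cc2c1C` differs from compound 2 by hydrogen in place of chloro on an aromatic carbon. Within the data shown here, the single measured step, which swaps one halophenyl for another on the sulfonyl sulfur, is the only guide; it shows that altering that aryl can push the number to the limit (the limit of > 40000 nM in this assay, at which 1 of the 2 values shown sits), but it says nothing direct about removing the chloro entirely. No step beyond the scatter is expected in this assay in either direction. Compound 3 is expected to remain near the limit, an at least 1.3-fold lower number from compound 2 to compound 3 (0.12 log units; that floor lies within the scatter). Compound 3 is estimated at 30000 nM, within 8000 nM to 100000 nM.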

Compound 3, half-maximal inhibitory concentration: > 40000 nM
Compound 3 gave a limit, no number; the forecaster's own chance of this, stated with the estimate: 55%; middle value at least 1.3-fold (0.12 log units) away from the limit.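

In this assay, compound 3 gives only a limit, > 40000 nM. Removing the halogen from this ring therefore brings no measurable number back, and among the three compounds only the 4-bromophenyl of compound 1 gives a measured value. Replacing its bromo with hydrogen gives an at least 4.5-fold higher number from compound 1 to compound 3 (0.66 log units; beyond the scatter), which shows that the loss seen with the 3-chlorophenyl also appears with plain phenyl, while the step from the chloro to hydrogen cannot be read, as both of its values are limits: the limit of > 40000 nM in this assay, at which 2 of the 3 values shown sit.

On these data alone, it remains open whether the measured value of compound 1 depends on bromo itself or whether another group in its place, such as chloro, methoxy or an amine, would also give a number. As far as these compounds go, how far compound 2 and compound 3 lie beyond the limit also stays unknown.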